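Moving the chlorine on the aminoanilide series

A few compounds are considered here, and "the series" means these few. Any claim that something is new, unique, unknown or untested is made for them only; others in the source may bear on it.

Compound 1, `O=C(CCCCCCc1nc(-c2ccccc2Cl)no1)NO`: in an assay on isolated protein for inhibition of histone deacetylase 8 (Homo sapiens), read by fluorescence, with a stated time of 10 min (a higher number here means a weaker inhibitor, a lower number a stronger inhibitor), compound 1 gives 3650 nM.
Compound 2, `Nc1ccccc1NC(=O)CCCCCCc1nc(-c2ccccc2)no1`: compound 2 gives > 10000 nM, which is a limit of this assay and not a number.
Compound 3, `Nc1ccccc1NC(=O)CCCCCCc1nc(-c2ccc(Cl)cc2)no1`: compound 3 gives > 10000 nM, again a limit and not a number.

Compound 3 therefore stands at the limit of this assay, and it shares that position with compound 2; only compound 1 gives a number. Going by the values given here, the one measured step that touches this series, a step that the two limits leave unreadable from compound 2 to compound 3, cannot be read because both ends are limits (the limit of > 10000 nM in this assay, at which 2 of the 3 values shown sit).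

Compound 4, `Nc1ccccc1NC(=O)CCCCCCc1nc(-c2ccccc2Cl)no1`, is not yet measured. It differs from compound 3 by 2-chlorophenyl in place of 4-chlorophenyl on an aromatic carbon. Among the compounds with values here, no measured step reports this change directly; the only chloro step, a step that the two limits leave unreadable from compound 2 to compound 3, has a size that cannot be read. Compound 1 carries the same 2-chlorophenyl group as compound 4 but differs from it in a second place as well; compound 1 gives 3650 nM, which stands beside compound 4 only as a value, not as a step.

With both aminoanilides at the limit, compound 4 is expected to sit near the limit too, and the step that the limit leaves unreadable from compound 3 to compound 4 is expected to be small or unreadable. The estimate for compound 4 is 20000 nM, within 7000 nM to 60000 nM.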

Compound 4, half-maximal inhibitory concentration: > 10000 nM
Compound 4: no number, only a limit (the forecaster's own chance of this, stated with the estimate: 75%); the middle value lies beyond the limit too.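

In this assay compound 4 gives only a limit and not a number, so 2-chlorophenyl in place of 4-chlorophenyl on this aromatic carbon brings no aminoanilide here to a readable value: the limit of > 10000 nM in this assay, at which 3 of the 4 values shown sit. The steps to compound 4 from compound 3 and from compound 2 cannot be read, as both ends of each are limits. Going by these compounds alone, the 2-chlorophenyl group does allow one reading that the earlier compounds did not: with that group held in place, 2-aminophenyl in place of hydroxy on the amide-type nitrogen gives an at least 2.7-fold higher number from compound 1 to compound 4 (0.43 log units; beyond the scatter) and this is a bound on the step and not its full size.

On these data alone, whether 2-chlorophenyl and 4-chlorophenyl differ at all on this core stays open, as does how far past the limit any of the aminoanilides lies. Also open, as far as these compounds go, is what 3-chlorophenyl, a fluorophenyl or a methoxyphenyl at this place, or a shorter chain on the core of compound 4, would give in this assay and whether any of these would bring an aminoanilide to a number.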